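From a Methylphenyl to a Chlorophenyl Group

The source may report more compounds than this note shows. Statements on the series, on what has been measured and on what is new or still open speak of the compounds shown alone.

Three compounds share one core and differ only in the aryl group on an aromatic nitrogen. In a functional assay on HepG2 cells (Homo sapiens) for inhibition, read by MTT assay, with a stated time of 72 h (on this read-out higher numbers stand for weaker inhibition and lower numbers for stronger inhibition), compound 2 `Cc1ccc(-n2cc(COc3cccc(NC(=O)Nc4ccc(Cl)c(C(F)(F)F)c4)c3)nn2)cc1` gives 5430 nM, the lowest of the three numbers, although compound 1 `Cc1cccc(-n2cc(COc3cccc(NC(=O)Nc4ccc(Cl)c(C(F)(F)F)c4)c3)nn2)c1` with 7270 nM sits within the scatter, as a 1.3-fold lower number from compound 1 to compound 2 (0.13 log units; within the scatter) shows. Compound 3 `CCc1cccc(-n2cc(COc3cccc(NC(=O)Nc4ccc(Cl)c(C(F)(F)F)c4)c3)nn2)c1` gives 37900 nM, and a 7.0-fold higher number from compound 2 to compound 3 (0.84 log units; beyond the scatter). Compound 4 `O=C(Nc1cccc(OCc2cn(-c3cccc(Cl)c3)nn2)c1)Nc1ccc(Cl)c(C(F)(F)F)c1` carries the change (3-chlorophenyl in place of 4-methylphenyl on an aromatic nitrogen). Going by the values given here, no measured step tests a chlorine at this place; the two steps that bear on it show that shifting the methyl changes nothing beyond the scatter, while an ethyl in place of methyl raises the number modestly. A small step at most is therefore expected: a 1.3-fold higher number from compound 2 to compound 4 (0.11 log units; within the scatter). Compound 4 is estimated at 7000 nM, with a range from 2500 nM to 20000 nM.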

Compound 4, half-maximal inhibitory concentration: 2020 nM
Compound 4: the middle estimate sits 3.5-fold (0.54 log units) above what was measured, outside the stated range (below it).
By their numbers in this assay, from the lowest: compound 4; then compounds 2 and 1 (each within the scatter of the next); then compound 3.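

In this assay a change at this position can lower the number beyond the scatter, which no earlier step had shown: 3-chlorophenyl gives a 2.7-fold lower number from compound 2 to compound 4 (0.43 log units; beyond the scatter) and a 3.6-fold lower number from compound 1 to compound 4 (0.56 log units; beyond the scatter) while the swap from ethyl gives a 19-fold lower number from compound 3 to compound 4 (1.27 log units; beyond the scatter) so that compound 4 stands as the most potent of the four. Chloro and methyl on the same ring carbon are thus not interchangeable here. No measurement shown explains this difference.

Going by these compounds, whether fluoro, bromo or methoxy in place of the chloro would lower the number further stays open. So does how 4-chlorophenyl would compare with 3-chlorophenyl.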